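The source may report more compounds than this note shows. Statements on the series, on what has been measured and on what is new or still open speak of the compounds shown alone.

In a functional assay on PC-3 cells (Homo sapiens) for cytotoxicity, read by WST assay, with a stated time of 72 h (a lower number here means a stronger inhibitor, a higher number a weaker inhibitor), compound 1 `O=C1Nc2ccccc2C1(c1ccc(O)cc1)C1CCCCCC1` gives > 1000 nM, which is a limit of the assay and not a number. Compound 2 `Cc1cccc2c1NC(=O)C2(c1ccc(O)cc1)C1CCCCCC1` gives > 1000 nM, again a limit. Within the data shown here, compound 3 `O=C1Nc2c(C(F)(F)F)cccc2C1(c1ccc(O)cc1)C1CCCCCC1` gives 91 nM, the only true number so far, and it is the most potent compound here. The measured changes all sit on an aromatic carbon. Methyl in place of hydrogen gives a step that the two limits leave unreadable from compound 1 to compound 2. Trifluoromethyl in place of hydrogen gives an at least 10-fold lower number from compound 1 to compound 3 (1.04 log units; beyond the scatter), and trifluoromethyl in place of methyl gives an at least 10-fold lower number from compound 2 to compound 3 (1.04 log units; beyond the scatter). The remaining reference point is the limit of > 1000 nM in this assay, at which 2 of the 3 values shown sit.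

Compound 4 `O=C1Nc2c(C(F)(F)F)cccc2C1(c1ccc(O)cc1)n1ccnc1` keeps the aromatic trifluoromethyl of compound 3 and carries 1H-imidazol-1-yl in place of cycloheptyl on a saturated ring carbon. Among the measured compounds shown here, no measured step covers a change at this saturated ring carbon, so the size of this step rests on weak ground. For the measured compounds named here, the large steps show only that a single change can move this series a long way, as with compound 1 in an at least 10-fold lower number from compound 1 to compound 3 (1.04 log units; beyond the scatter). A weaker result is expected, with a wide margin, and the assay limit may be reached. The expected change is a 4.9-fold higher number from compound 3 to compound 4 (0.69 log units; beyond the scatter). For compound 4 the estimated value is 450 nM, with an expected range of 80 nM to 3000 nM.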

Compound 4, half-maximal inhibitory concentration: > 1000 nM
Compound 4: a limit, no number (the forecaster's own chance of this, stated with the estimate: 35%); at least 2.2-fold (0.34 log units) between middle value and limit.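

In this assay, the saturated ring carbon now has its first measured step: 1H-imidazol-1-yl in place of cycloheptyl gives an at least 10-fold higher number from compound 3 to compound 4 (1.04 log units; beyond the scatter). The aromatic trifluoromethyl is present in both compounds, so it does not by itself secure a measurable value in this series, and the group on the saturated ring carbon can also decide the result. Compound 4 gives > 1000 nM, which is a limit of the assay and not a number, and it adds to the compounds without a true value: the limit of > 1000 nM in this assay, at which 3 of the 4 values shown sit.

Cycloheptyl and 1H-imidazol-1-yl differ at once in ring size, aromatic character and hetero atoms, so this one step cannot show which of these differences accounts for the change, nor how far the value lies past the limit. Cyclohexyl, phenyl or a dimethylamino group on this saturated ring carbon, with the trifluoromethyl kept, would begin to separate these differences, and the compounds shown leave open whether any group other than cycloheptyl gives a true value here.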